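Swapping ethylamino for dimethylamino on a shared core

A few compounds are considered here, and "the series" means these few. Any claim that something is new, unique, unknown or untested is made for them only; others in the source may bear on it.

Compound 1 `N[C@@H]1CCCc2onc(O)c21` gives 281000 nM
Compound 2 `CCNC1CCCc2onc(O)c21` gives 278000 nM

In a functional assay with Mus musculus as the target (on this read-out lower numbers stand for stronger inhibition and higher numbers for weaker inhibition), compound 2 at 278000 nM stands level with compound 1 at 281000 nM and the gap between them lies within the usual scatter. Compound 3 `CN(C)C1CCCc2onc(O)c21` is not yet measured. It has the same atoms as compound 2, joined differently, with dimethylamino in place of ethylamino on a saturated ring carbon. Among the compounds with values here, no measured step between close relatives is available, so nothing yet shows how strongly this assay responds to such a swap. The expectation is therefore modest, with no change beyond the scatter in either direction. The expected move is a 1.2-fold higher number from compound 2 to compound 3 (0.06 log units; within the scatter) and it starts from compound 2 at 278000 nM with a wide margin. For compound 3 the estimated value is 320000 nM with 110000 nM to 900000 nM as the expected range.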

Compound 3, half-maximal inhibitory concentration: > 500000 nM
Compound 3: a limit, no number; the forecaster's own chance of this, stated with the estimate: 20%; at least 1.5-fold (0.19 log units) between middle value and limit.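

In this assay, compound 3 gives > 500000 nM, which is a limit of the assay and not a number. Within the data shown here, this yields the first step between close relatives at this saturated ring carbon: an at least 1.7-fold higher number from compound 2 to compound 3 (0.25 log units; that floor lies within the scatter). Dimethylamino carries no hydrogen-bond donor where ethylamino carries one, and this swap brings no gain in inhibition, although the printed floor alone does not establish a loss beyond the scatter. The true size of the step stays hidden: the limit of > 500000 nM in this assay, at which 1 of the 3 values shown sits.

Open, on these data alone, is whether the missing hydrogen-bond donor or the changed arrangement of the same atoms matters here, since the swap alters both together. Methylamino or a longer chain such as propylamino on the same ring carbon could help separate the two.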